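The source may report more compounds than this note shows. Statements on the series, on what has been measured and on what is new or still open speak of the compounds shown alone.

Three compounds share one core. Compound 1 `CC(C)CN(CC(C)C)N1CCN(c2nc(=O)c3cc(C(F)(F)F)cc([N+](=O)[O-])c3s2)CC1` in an ADME assay on Vero cells (Chlorocebus sabaeus) for cytotoxicity, read by MTT assay, with a stated time of 72 h (a higher number here means that more compound is tolerated, a lower number that less compound is tolerated), gives > 64 ug/mL, which is a limit of the assay rather than a number. Compound 2 `O=c1nc(N2CCN(NCc3ccc(F)cc3)CC2)sc2c([N+](=O)[O-])cc(C(F)(F)F)cc12` in this assay likewise gives only the limit > 64 ug/mL. Compound 3 `Cc1cccc(F)c1CNN1CCN(c2nc(=O)c3cc(C(F)(F)F)cc([N+](=O)[O-])c3s2)CC1` in this assay also reaches only the limit > 64 ug/mL. The steps a step that the two limits leave unreadable from compound 1 to compound 2, a step that the two limits leave unreadable from compound 1 to compound 3 and a step that the two limits leave unreadable from compound 2 to compound 3 therefore cannot be sized because all three values sit at the limit of > 64 ug/mL in this assay, at which 3 of the 3 values shown sit. Compound 4 `O=c1nc(N2CCN(Nc3ccc(OC(F)(F)F)cc3)CC2)sc2c([N+](=O)[O-])cc(C(F)(F)F)cc12` differs from compound 3 by 4-(trifluoromethoxy)phenyl in place of 2-fluoro-6-methylbenzyl on an amine nitrogen. For the measured compounds named here, no measured step bears readably on this change, so no movement beyond the scatter is anticipated. Compound 4 is expected to give about 80 ug/mL in this assay, within 32 ug/mL to 200 ug/mL, an estimated step that the limit leaves unreadable from compound 3 to compound 4 that will most likely again be reported only as a limit.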

Compound 4, half-maximal cytotoxic concentration: > 64 ug/mL
Compound 4: only a limit was reported; the forecaster's own chance of this, stated with the estimate: 75%; the middle value lies beyond the limit too.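

Compound 4 in this assay gives > 64 ug/mL, again a limit of the assay. Its steps from compound 1, compound 2 and compound 3 cannot be read because no value falls short of that limit: the limit of > 64 ug/mL in this assay, at which 4 of the 4 values shown sit. The compounds shown leave open where any of the four would reach its half-maximal cytotoxic concentration, and whether they differ at all.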